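Naphthalen-2-yl to benzyl on the amine nitrogen

The compounds below may be only part of what the source reports. "The series", "measured", "known", "first", "only" and "open" are said of these compounds alone.

In a functional assay on A-375 cells (Homo sapiens) for cytotoxicity, read by MTT assay, with a stated time of 24 h (on this read-out lower numbers stand for stronger inhibition and higher numbers for weaker inhibition), compound 1 `COc1cc(C)cc2c1C(=O)C=C(c1c(C)cc3c(c1OC)C(=O)C(Nc1ccc(Cl)cc1)=CC3=O)C2=O` gives 630 nM and compound 2 `COc1cc(C)cc2c1C(=O)C=C(c1c(C)cc3c(c1OC)C(=O)C(Nc1ccc4ccccc4c1)=CC3=O)C2=O` gives 80 nM, the lower of the two numbers. Compound 3 `COc1cc(C)cc2c1C(=O)C=C(c1c(C)cc3c(c1OC)C(=O)C(NCc1ccccc1)=CC3=O)C2=O` carries benzyl in place of naphthalen-2-yl on an amine nitrogen. Among the measured compounds shown here, only one measured step bears on this place, a 7.9-fold lower number from compound 1 to compound 2 (0.90 log units; beyond the scatter), which is modest but beyond the scatter and came with the arrival of naphthalen-2-yl. Losing that group is therefore expected to raise the number in this assay by a similar or smaller amount, an expected 3.1-fold higher number from compound 2 to compound 3 (0.49 log units; beyond the scatter). For compound 3 the estimate is 250 nM, with an expected range of 70 nM to 900 nM.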

Compound 3, half-maximal inhibitory concentration: 550 nM
The estimate for compound 3 lay 2.2-fold (0.34 log units) below the measured number; low and high end bracket the measured number.
By their numbers in this assay, from the lowest: compound 2; then compounds 3 and 1 (each within the scatter of the next).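

In this assay, benzyl on the amine nitrogen does not keep the low number seen with naphthalen-2-yl, giving a 6.9-fold higher number from compound 2 to compound 3 (0.84 log units; beyond the scatter). Benzyl and 4-chlorophenyl instead read alike, with a 1.1-fold lower number from compound 1 to compound 3 (0.06 log units; within the scatter), so among these three groups only naphthalen-2-yl stands apart. No supporting data explain the difference between these groups. From the compounds shown here alone, whether the second aromatic ring or direct attachment to the amine nitrogen matters remains open. A naphthalen-2-ylmethyl group and an unsubstituted phenyl group would help separate the two.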